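Methoxymethyl in Place of Tert-Butyl on the Triazole Carbon

The source may hold more compounds than are shown below. What is called first, only, known or untested is meant among the compounds shown, and "the series" means these compounds.

Measured compounds:
compound 1, `CCCc1nnc2c(C#N)c(N3CCC(c4ccccc4)CC3)ccn12` — 299 nM
compound 2, `N#Cc1c(N2CCC(c3ccccc3)CC2)ccn2c(CC(F)(F)F)nnc12` — 56 nM
compound 3, `CC(C)(C)c1nnc2c(C#N)c(N3CCC(c4ccccc4)CC3)ccn12` — 1230 nM

In a functional assay on CHO cells for positive allosteric modulation of metabotropic glutamate receptor 2 (Homo sapiens), read by GTPgammaS binding, with a stated time of 30 min (a higher number here means that more compound is needed for the effect, a lower number that less compound is needed), compound 3 gives the highest number of the three, and both gaps to it lie beyond the scatter: a 4.1-fold higher number from compound 1 to compound 3 (0.61 log units; beyond the scatter) and a 22-fold higher number from compound 2 to compound 3 (1.34 log units; beyond the scatter). Compound 1 and compound 2 also differ from each other, a 5.3-fold lower number from compound 1 to compound 2 (0.73 log units; beyond the scatter).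

The next compound, compound 4 `COCc1nnc2c(C#N)c(N3CCC(c4ccccc4)CC3)ccn12`, is not yet measured. It keeps the shared core and the phenylpiperidine and changes only the group on the five-membered ring: methoxymethyl in place of tert-butyl on an aromatic carbon.

Among the compounds with values here, two measured steps bear on this. Both steps into compound 3 went to a higher number, the one from propyl modest and the one from 2,2,2-trifluoroethyl large. The group entering in compound 4 is an unbranched chain of three heavy atoms, as propyl is, so the change from compound 3 to compound 4 is expected to roughly reverse the step seen from compound 1 to compound 3, giving a modestly lower number in this assay. The acceptor in methoxymethyl has no measured counterpart among these three compounds, which widens the range.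

For compound 4 the estimated value in this assay is 300 nM, with a range from 90 nM to 1000 nM, which corresponds to an expected step of a 4.1-fold lower number from compound 3 to compound 4 (0.61 log units; beyond the scatter).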

Compound 4, half-maximal effective concentration: 468 nM
Beside the measured number, compound 4's estimate is 1.6-fold (0.19 log units) below it; measured number inside the range.
By their numbers in this assay, from the lowest: compound 2; then compounds 1 and 4 (each within the scatter of the next); then compound 3.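

In this assay, methoxymethyl in place of tert-butyl on this aromatic carbon, which lies between two ring nitrogen atoms, gives a 2.6-fold lower number from compound 3 to compound 4 (0.42 log units; beyond the scatter), so compound 4 recovers part of what separates compound 3 from compound 1. Methoxy in place of ethyl on the saturated chain carbon gives a 1.6-fold higher number from compound 1 to compound 4 (0.19 log units; within the scatter), so the hydrogen-bond acceptor that enters with methoxymethyl leaves the number within the scatter of the propyl compound, and the estimate's wider range for that acceptor was not needed here. Methoxy in place of trifluoromethyl on that same chain carbon gives an 8.4-fold higher number from compound 2 to compound 4 (0.92 log units; beyond the scatter), which shows that the low number of compound 2 goes with its trifluoromethyl end and is not shared by the other unbranched group with a heteroatom.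

Nothing available explains why these groups order as they do in this assay. The compounds shown leave open whether a longer chain, a dimethylaminomethyl group or a difluoromethyl group on this carbon would stay with compounds 1 and 4 or come closer to compound 2.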